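Ester to amide on the pyrrolidine: compound 4 expected

This account rests on a few compounds, and the source may have more. Where it says the series, first, only, none or still open, it means among the compounds named here.

Measured so far:
compound 1 `COC(=O)CNC(=O)NCc1ccc(C(=O)N2CCCCc3ccccc32)cc1C`: 37 nM
compound 2 `CCOC(=O)CNC(=O)NCc1ccc(C(=O)N2CCCCc3ccccc32)cc1C`: 140 nM
compound 3 `COC(=O)[C@@H]1CCCN1C(=O)NCc1ccc(C(=O)N2CCCCc3ccccc32)cc1C`: 100 nM

All three share one core and differ only in the group attached to the urea carbonyl. In a functional assay on HEK293 cells for agonist activity at Vasopressin V2 receptor (Homo sapiens), read by a luciferase reporter and cAMP accumulation (on this read-out lower numbers stand for an effect already at smaller amounts and higher numbers for an effect only at larger amounts of compound), compound 1 gives 37 nM, compound 2 gives 140 nM and compound 3 gives 100 nM. Compound 3 thus holds the second highest number of the three: it stands close to compound 2, as a 1.4-fold lower number from compound 2 to compound 3 (0.15 log units; within the scatter) shows, while a 2.7-fold higher number from compound 1 to compound 3 (0.43 log units; beyond the scatter) separates it clearly from compound 1.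

Compound 4 `Cc1cc(C(=O)N2CCCCc3ccccc32)ccc1CNC(=O)N1CCC[C@@H]1C(=O)N(C)C` changes the same position again: 2-(dimethylcarbamoyl)pyrrolidin-1-yl in place of 2-(methoxycarbonyl)pyrrolidin-1-yl on a carbonyl carbon. For the measured compounds named here, no measured pair swaps an ester for an amide, so the closest guides are indirect. a 3.8-fold higher number from compound 1 to compound 2 (0.58 log units; beyond the scatter) shows that even a small enlargement of the ester alkyl chain moved the number modestly, and a 2.7-fold higher number from compound 1 to compound 3 (0.43 log units; beyond the scatter) shows a ring in place of the open chain did likewise. Both steps were modest, so the expectation for a 1.5-fold higher number from compound 3 to compound 4 (0.18 log units; within the scatter) is a change of similar or smaller size, direction uncertain. Compound 4 is therefore estimated at 150 nM, with a range from 40 nM to 600 nM.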

Compound 4, half-maximal effective concentration: 380 nM
Compound 4: middle estimate off by 2.5-fold (0.40 log units), on the low side; measured number inside the range.
By their numbers in this assay, from the lowest: compound 1; then compounds 3 and 2 (each within the scatter of the next); then compound 4.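

For the compounds shown here, exchanging the ester for the dimethyl amide on the pyrrolidine gives a 3.8-fold higher number from compound 3 to compound 4 (0.58 log units; beyond the scatter) and is the first direct reading of this swap on the group attached to the carbonyl carbon. The new group also stands clear of the open-chain ethyl ester, with a 2.7-fold higher number from compound 2 to compound 4 (0.43 log units; beyond the scatter) on record, while the full distance from the open-chain methyl ester is a 10-fold higher number from compound 1 to compound 4 (1.01 log units; beyond the scatter) and is the only large step among these compounds, so the step to the ring and the step to the amide run the same way. Nothing at hand explains why the amide gives the higher number.

Open, as far as these compounds go, is where a carboxylic acid, or an amide with a single methyl on its nitrogen, would fall on the pyrrolidine. Also open, from the compounds shown here alone, is whether the same swap on the open chain would give a step of similar size.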